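Taking One Hydroxy Group from Compound 3

The compounds below may be only part of what the source reports. "The series", "measured", "known", "first", "only" and "open" are said of these compounds alone.

In a functional assay on PC-3 cells (Homo sapiens) for cytotoxicity, read by MTT assay, with a stated time of 72 h (a lower number here means a stronger inhibitor, a higher number a weaker inhibitor), compound 1 `O=C(N/N=C/c1ccc(F)cc1Cl)Nc1cc2c(Nc3ccc(F)c(Cl)c3)ncnc2cc1O[C@H]1CCOC1` gives 28400 nM and compound 2 `COc1cc(/C=N/NC(=O)Nc2cc3c(Nc4ccc(F)c(Cl)c4)ncnc3cc2O[C@H]2CCOC2)cc(OC)c1OC` gives 29600 nM, with a 1.0-fold higher number from compound 1 to compound 2 (0.02 log units; within the scatter). Compound 3 `O=C(N/N=C/c1ccc(O)cc1O)Nc1cc2c(Nc3ccc(F)c(Cl)c3)ncnc2cc1O[C@H]1CCOC1` has the lowest number of the three, at 7540 nM. The steps of a 3.8-fold lower number from compound 1 to compound 3 (0.58 log units; beyond the scatter) and a 3.9-fold lower number from compound 2 to compound 3 (0.59 log units; beyond the scatter) are modest, and each brings in the 2,4-dihydroxyphenyl group. Compound 4 `O=C(N/N=C/c1ccc(O)cc1)Nc1cc2c(Nc3ccc(F)c(Cl)c3)ncnc2cc1O[C@H]1CCOC1` has 4-hydroxyphenyl there instead, with hydrogen in place of hydroxy on an aromatic carbon, ortho to a large group: hydrogen in place of hydroxy on an aromatic carbon. Within the data shown here, no measured step removes a single hydroxy, so those two steps serve only as an outer bound. The expected change is smaller than those two steps, toward a higher number: a 1.9-fold higher number from compound 3 to compound 4 (0.27 log units; within the scatter). For compound 4 the estimated value is 14000 nM, with an expected range of 6000 nM to 32000 nM.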

Compound 4, half-maximal inhibitory concentration: 4890 nM
For compound 4 the middle estimate is 2.9-fold (0.46 log units) above the measured one, outside the stated range (below it).
By their numbers in this assay, from the lowest: compounds 4 and 3 (each within the scatter of the next); then compounds 1 and 2 (each within the scatter of the next).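

In this assay, the hydroxy group ortho to a large group can give way to hydrogen without a change beyond the scatter, with a 1.5-fold lower number from compound 3 to compound 4 (0.19 log units; within the scatter), so a second hydroxy group on this ring is not needed for the lower numbers seen here. Among these compounds, the single remaining hydroxy group still leaves clear steps from the other two aryl groups, with a 6.1-fold lower number from compound 2 to compound 4 (0.78 log units; beyond the scatter) and a 5.8-fold lower number from compound 1 to compound 4 (0.76 log units; beyond the scatter). No measurement at hand offers a reason for this result. The compounds shown leave open how an amine or a carboxylic acid would fare on this aromatic carbon. They also leave open whether the remaining hydroxy group matters at all, since no phenyl ring without it appears among them.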